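Putting a halogen back on a weak compound

A few compounds are considered here, and "the series" means these few. Any claim that something is new, unique, unknown or untested is made for them only; others in the source may bear on it.

Among the measured compounds shown here, in a functional assay on SK-BR-3 cells (Homo sapiens) for antiproliferative activity, with a stated time of 72 h (on this read-out higher numbers stand for weaker inhibition of growth and lower numbers for stronger inhibition of growth), compound 2 `COc1cc(CN(C)C(=O)c2cc(Cl)c(O)cc2O)cc(OC)c1OC` gives 30100 nM as the higher of the two numbers so far, while compound 1 `COc1cc(CN(C)C(=O)c2cc(Cl)c(O)cc2O)c(Cl)c(OC)c1OC` gives 2400 nM as the lower one. Compound 3 `COc1cc(CN(C)C(=O)c2cc(Cl)c(O)cc2O)c(Br)c(OC)c1OC` is not yet measured and carries bromo in place of hydrogen on an aromatic carbon of compound 2 (bromo in place of hydrogen on an aromatic carbon). For the measured compounds named here, the only measured step that bears on this is a 13-fold higher number from compound 1 to compound 2 (1.10 log units; beyond the scatter) with hydrogen in place of chloro. Read backwards, this large step suggests a large fall in the number in this assay for the bromo compound. The expected change is a 15-fold lower number from compound 2 to compound 3 (1.18 log units; beyond the scatter) by this estimate. The estimate for compound 3 is 2000 nM (expected range 600 nM to 7000 nM).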

Compound 3, concentration for 50% growth inhibition: 7700 nM
Compound 3: the middle estimate sits 3.9-fold (0.59 log units) below what was measured, outside the stated range (above it).
By their numbers in this assay, from the lowest: compound 1; then compound 3; then compound 2.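

In this assay, there is a 3.9-fold lower number from compound 2 to compound 3 (0.59 log units; beyond the scatter), so the gain at this position is not unique to chloro: bromo also lowers the number. The two halogens are still not interchangeable, since there is a 3.2-fold higher number from compound 1 to compound 3 (0.51 log units; beyond the scatter), and chloro gives the lower number of the pair. Nothing measured here explains this difference between chloro and bromo. Still open, on these data alone, is how fluoro, iodo or a methyl group would behave on this same aromatic carbon. An amine there, which is not a halogen at all, is equally untested among the compounds shown.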